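This account rests on a few compounds, and the source may have more. Where it says the series, first, only, none or still open, it means among the compounds named here.

Compound 1 `COc1ccc(N(C)c2nccc(-c3ccncc3)n2)cc1` carries a methyl on a nitrogen on an aromatic ring. In a functional assay for inhibition, with Homo sapiens as the target (a higher number here means a weaker inhibitor, a lower number a stronger inhibitor), compound 1 gives > 24000 nM, which is a limit of the assay and not a number (the limit of > 24000 nM in this assay, at which 1 of the 3 values shown sits). Compound 2 `COc1ccc(Nc2nccc(-c3ccncc3)n2)cc1` has hydrogen in place of methyl on a nitrogen on an aromatic ring, and in this assay compound 2 gives 4200 nM, so that the change gave an at least 5.7-fold lower number from compound 1 to compound 2 (0.75 log units; beyond the scatter). Compound 3 `CC(=O)N(C)c1ccc(Nc2nccc(-c3ccncc3)n2)cc1` differs from compound 2 by acetyl(methyl)amino in place of methoxy on an aromatic carbon; in this assay compound 3 gives 500 nM, a step of an 8.4-fold lower number from compound 2 to compound 3 (0.92 log units; beyond the scatter). The difference between the core of compound 1 and the core of compound 3 is not broken down here.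

Compound 4 `CC(=O)Nc1ccc(Nc2nccc(-c3ccncc3)n2)cc1` is not yet measured. It differs from compound 3 by hydrogen in place of methyl on an amide-type nitrogen. This is the same kind of change as from compound 1 to compound 2, not the same one: there the nitrogen's other neighbours were aromatic carbon and aromatic carbon, here they are aromatic carbon and carbonyl carbon. Compound 4 is expected to show a 2.0-fold lower number from compound 3 to compound 4 (0.30 log units; within the scatter) in this assay, a smaller step than the earlier at least 5.7-fold lower number from compound 1 to compound 2 (0.75 log units; beyond the scatter), which rests on that earlier step read with caution for the different place. The estimate for compound 4 in this assay is 250 nM, expected to lie between 80 nM and 1000 nM.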

Compound 4, half-maximal inhibitory concentration: 5300 nM
Estimate against measurement, compound 4: 21-fold (1.33 log units) below, and the stated range ends below it.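

In this assay, the same swap of methyl for hydrogen, now on an amide-type nitrogen, gave an 11-fold higher number from compound 3 to compound 4 (1.03 log units; beyond the scatter), so it did not carry over from the earlier nitrogen, and the two steps clearly differ: the same change on two cores in this assay, an at least 5.7-fold lower number (0.75 log units; beyond the scatter) from compound 1 to compound 2 and an 11-fold higher number (1.03 log units; beyond the scatter) from compound 3 to compound 4, at least 60-fold (1.78 log units) apart, beyond the scatter of two such steps. With the methyl gone, acetamido in place of methoxy stays within the scatter, a 1.3-fold higher number from compound 2 to compound 4 (0.10 log units; within the scatter), so the gain seen with acetyl(methyl)amino is lost in this pair. This rests on only two places, and the value of compound 1 is a limit of the assay, so the size of the earlier step stays unknown, and neither the reason for the difference nor a rule for other cores follows: the limit of > 24000 nM in this assay, at which 1 of the 4 values shown sits.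

As far as these compounds go, it remains open whether the methyl on the amide-type nitrogen is special or whether an ethyl there would serve as well. From the compounds shown here alone, it is equally open how a longer acyl chain, such as propionyl, in place of the acetyl would read in this assay.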